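Chlorophenyl swap on two cores, one measured step

A few compounds are considered here, and "the series" means these few. Any claim that something is new, unique, unknown or untested is made for them only; others in the source may bear on it.

Compound 1 `O=C(NNC(=O)c1ccccc1Cl)c1ccc(NS(=O)(=O)c2cnc(O)nc2O)cc1` and compound 2 `O=C(NNC(=O)c1cccc(Cl)c1)c1ccc(NS(=O)(=O)c2cnc(O)nc2O)cc1` share one core; compound 3 `O=C(NNC(=O)c1ccccc1NS(=O)(=O)c1cnc(O)nc1O)c1ccccc1Cl` and compound 4 `O=C(NNC(=O)c1ccccc1NS(=O)(=O)c1cnc(O)nc1O)c1cccc(Cl)c1` share another. The difference between the two cores is not broken down here. In a functional assay on OVCAR-3 cells (Homo sapiens) for antiproliferative activity, read by MTT assay, with a stated time of 24 h (a higher number here means a weaker inhibitor, a lower number a stronger inhibitor), compound 1 gives 5220 nM and compound 2 gives 7710 nM; the change 3-chlorophenyl in place of 2-chlorophenyl on a carbonyl carbon made a step of a 1.5-fold higher number from compound 1 to compound 2 (0.17 log units; within the scatter). Compound 3 gives 18200 nM in this assay, the highest number of the three measured. The change from compound 3 to compound 4 is the same change, (3-chlorophenyl in place of 2-chlorophenyl on a carbonyl carbon), made on the second core. Because a 1.5-fold higher number from compound 1 to compound 2 (0.17 log units; within the scatter) stayed within the scatter, the step of a 1.3-fold higher number from compound 3 to compound 4 (0.12 log units; within the scatter) is expected to be of similar size. Compound 4 is accordingly estimated at 24000 nM, with a range from 11000 nM to 55000 nM in this assay.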

Compound 4, half-maximal inhibitory concentration: 2080 nM
Beside the measured number, compound 4's estimate is 12-fold (1.06 log units) above it; the whole stated range lies above it.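

In this assay, 3-chlorophenyl in place of 2-chlorophenyl on a carbonyl carbon gives an 8.8-fold lower number from compound 3 to compound 4 (0.94 log units; beyond the scatter). The change does not carry over between these two cores, and its size on the core of compound 1 does not predict its size on the core of compound 3: the same change on two cores in this assay, a 1.5-fold higher number (0.17 log units; within the scatter) from compound 1 to compound 2 and an 8.8-fold lower number (0.94 log units; beyond the scatter) from compound 3 to compound 4, 13-fold (1.11 log units) apart, beyond the scatter of two such steps This rests on a single pair per core in one cell assay, so it shows that the step depends on the core for these four compounds, but not why it does.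

As far as these compounds go, whether other groups on that carbonyl carbon, such as a fluorophenyl or a methoxyphenyl, also behave differently on the two cores remains open. So does whether the same difference appears in other cell lines.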